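Imidazolyl thioether in place of aminophenyl thioether

A few compounds are considered here, and "the series" means these few. Any claim that something is new, unique, unknown or untested is made for them only; others in the source may bear on it.

For the measured compounds named here, compound 1 `Nc1ccc(SCC(=O)Nc2ccc3nc(NC(=O)c4ccc(C(F)(F)F)cc4)sc3c2)cc1` stands lowest of the three numbers so far in a functional assay on HCT-116 cells (Homo sapiens) for antiproliferative activity, read by MTT assay, with a stated time of 72 h (a lower number here means a stronger inhibitor, a higher number a weaker inhibitor), where compound 1 gives 100 nM. The nearest is compound 3 `Oc1ccc(Cl)cc1/C=N/c1ccc(-c2nc3ccccc3o2)c(O)c1`, which gives 20100 nM in this assay, and the furthest is compound 2 `Cc1cc(C)cc(C(=O)Nc2nc3ccc(NC(=O)CSc4ccc(Cl)cc4)cc3s2)c1`, which gives 65100 nM; both gaps to compound 1 lie beyond the scatter. Going by the values given here, compound 2 shares the core of compound 1, but no single-change step connects the two, so only their two values are noted here.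

Compound 4 `O=C(CSc1ncc[nH]1)Nc1ccc2nc(NC(=O)c3ccc(C(F)(F)F)cc3)sc2c1` is the unmeasured member. Against compound 1 the change is 1H-imidazol-2-yl in place of 4-aminophenyl on a sulfur. Cut one bond further out it reads (4-aminophenyl)sulfanyl to (1H-imidazol-2-yl)sulfanyl. Among the compounds with values here, no measured pair in the set shows this exchange, and nothing here ties the sulfanyl substituent to the read-out.

The expectation is a modest weakening, estimated as a 4.0-fold higher number from compound 1 to compound 4 (0.60 log units; beyond the scatter), possibly not beyond the scatter. Compound 4 is thus expected to give about 400 nM in this assay, within 80 nM to 4000 nM.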

Compound 4, half-maximal inhibitory concentration: 2690 nM
The estimate for compound 4 lay 6.7-fold (0.83 log units) below the measured number; the measured number falls inside the stated range.
By their numbers in this assay, from the lowest: compound 1; then compound 4; then compound 3; then compound 2.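

For the compounds shown here, the sulfanyl substituent on this chain is a sensitive position: in this assay, putting 1H-imidazol-2-yl in place of 4-aminophenyl on the sulfur gives a 27-fold higher number from compound 1 to compound 4 (1.43 log units; beyond the scatter) and is the first single-change step. The hydrogen-bond donor and acceptor counts of the two groups are the same, so matching those counts does not hold the number at the level of compound 1. No measurement at hand explains the size of this step.

One exchange changes ring size and ring atoms together, so it cannot show which of them goes with the higher number. Plain phenyl or 4-hydroxyphenyl on the same sulfur would test whether the amine matters or the six-membered carbon ring alone is enough.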